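Adding a butyl group to compound 1

The source may hold more compounds than are shown below. What is called first, only, known or untested is meant among the compounds shown, and "the series" means these compounds.

Measured so far in a functional assay on MT4 cells (Homo sapiens) for cytotoxicity, read by MTT assay; a higher number here means that more compound is tolerated, a lower number that less compound is tolerated

Compound 1 (`Cc1c(O)nc(SCc2ccc(O)cc2)nc1Cc1c(Cl)cccc1Cl`) gives 41000 nM here
Compound 2 (`COc1ccc(CS(=O)(=O)c2nc(O)c(C)c(Cc3c(Cl)cccc3Cl)n2)cc1`) gives 2800 nM here

Compound 1 has the higher of these two numbers, and the gap down to compound 2 lies beyond the usual scatter. The two compounds differ in more than one place, so that gap cannot be tied to a single change. Compound 3 (`CCCCOc1ccc(CSc2nc(O)c(C)c(Cc3c(Cl)cccc3Cl)n2)cc1`) is compound 1 with butyl in place of hydrogen on an oxygen on an aromatic ring, which turns hydroxy to butoxy (butyl in place of hydrogen on an oxygen on an aromatic ring). Going by the values given here, no measured pair shows this change alone, so any forecast is uncertain. Compound 2, at 2800 nM, shows that a much lower number is possible with this shared core. A drop beyond the scatter is therefore expected in this assay, estimated as a step (a 3.4-fold lower number from compound 1 to compound 3 (0.53 log units; beyond the scatter)) toward less tolerated compound. Compound 3 is estimated at 12000 nM, with an expected range of 3500 nM to 40000 nM around it.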

Compound 3, half-maximal cytotoxic concentration: 3100 nM
Compound 3: middle estimate off by 3.9-fold (0.59 log units), on the high side, and the stated range ends above it.
By their numbers in this assay, from the lowest: compounds 2 and 3 (each within the scatter of the next); then compound 1.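

In this assay, going by these compounds alone, the change from hydroxy to butoxy gives a 13-fold lower number from compound 1 to compound 3 (1.12 log units; beyond the scatter) and is the first single change whose effect can be read on its own. It shows that this oxygen on the aromatic ring is a sensitive place, where butyl in place of hydrogen is enough on its own to move the number well beyond the scatter, toward less tolerated compound. Nothing available here explains why the number falls so far.

As far as these compounds go, with only hydrogen and butyl to compare on this oxygen, it remains open whether the number falls gradually as the chain grows or changes abruptly at some length. An ethyl or propyl group, a longer chain such as hexyl, or a chain ending in an amine or a carboxylic acid could help settle how the number depends on what sits there.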